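Cyclic amidine series: aryl switch at the chain carbon

This account rests on a few compounds, and the source may have more. Where it says the series, first, only, none or still open, it means among the compounds named here.

Measured so far:
compound 1, `c1ccc(C(/N=C2\CCCCCN2)C2CCCC2)cc1` — 12%
compound 2, `c1csc(C(/N=C2\CCCCCCN2)C2CC2)c1` — 17%

In a functional assay on the whole organism (plasma, strain Sprague-Dawley) with Rattus norvegicus as the target, with a stated time of 2 h, at a dose of 12.5 mg/kg by the oral route (a higher number here means a stronger effect of the compound at the dose given, a lower number a weaker effect), compound 1 gives 12%. Compound 2, with a different ring size in the core and a different pair of groups on the chain carbon, gives 17% in this assay; the two numbers lie within the scatter of each other, so neither stands apart. Both read-outs are small.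

Compound 3, `c1ccc(C(/N=C2\CCCCCN2)c2cccs2)cc1`, has not been measured. It differs from compound 1 in one place: thiophen-2-yl in place of cyclopentyl on a saturated chain carbon bound to an aromatic carbon and a double-bonded nitrogen. Among the compounds with values here, no measured pair in the set isolates this kind of exchange, so the size of the step cannot be read from the data. Given that compound 1 gives 12% and compound 2 gives 17% with no separation, the step from compound 1 to compound 3 is expected to stay within the scatter, a number 4 percentage points higher from compound 1 to compound 3 (within the scatter). Compound 3 is estimated at 16%, with a range from 2% to 34%, pending the measurement.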

Compound 3, a percentage reported as inhibition, in the whole organism at one dose (the size of the read-out at that dose, not a potency): 23%
Compound 3: middle estimate off by 7 percentage points, on the low side; the measured number falls inside the stated range.
By their numbers in this assay, from the lowest: compounds 1, 2 and 3 (each within the scatter of the next, the first and the last beyond it).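

Within the data shown here, the exchange of cyclopentyl for thiophen-2-yl on a saturated chain carbon bound to an aromatic carbon and a double-bonded nitrogen gives the first step that can be read, a number 11 percentage points higher from compound 1 to compound 3 (beyond the scatter), in this assay. The step is modest, but it shows that this position responds to a change that keeps the five-membered ring and the count of 5 heavy atoms, while the entering ring is aromatic and holds sulfur. No available evidence bears on why the read-out moves with this exchange.

Going by these compounds, whether the step follows aromaticity or sulfur stays open; furan-2-yl at this position would help separate the two. Also open, on these data alone, is whether the same exchange gives a similar step on the core of compound 2.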